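From compound 3 to compound 4: a benzyloxy swap

The source may report more compounds than this note shows. Statements on the series, on what has been measured and on what is new or still open speak of the compounds shown alone.

In an ADME assay on J774.A1 cells (Mus musculus) for inhibition, read by MTT assay, with a stated time of 72 h (a lower number here means that less compound is needed, a higher number that more compound is needed for the effect), compound 1 (`CNc1nc(NCc2ccccc2)nc2ccccc12`) gives 15000 nM, compound 2 (`Cc1ccc(CNc2nc(NCc3ccccc3)nc3ccccc23)cc1`) gives 2100 nM and compound 3 (`Clc1ccc(CNc2nc(NCc3ccccc3)nc3ccccc23)cc1`) gives 4600 nM, the second highest of the three numbers. Compound 4 (`c1ccc(CNc2nc(OCc3ccccc3)c3ccccc3n2)cc1`) is not yet measured. The change is benzyloxy in place of (4-chlorobenzyl)amino on an aromatic carbon. The nearest evidence is modest: a 7.1-fold lower number from compound 1 to compound 2 (0.85 log units; beyond the scatter), a 3.3-fold lower number from compound 1 to compound 3 (0.51 log units; beyond the scatter) and a 2.2-fold higher number from compound 2 to compound 3 (0.34 log units; beyond the scatter). None of these steps replaces nitrogen with oxygen at this place, so the data leave that part of the change untested. The expected result is a 1.2-fold higher number from compound 3 to compound 4 (0.08 log units; within the scatter), which would be no step beyond the scatter. Compound 4 is estimated at 5500 nM, with an expected range of 1800 nM to 16000 nM.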

Compound 4, half-maximal effective concentration: 3300 nM
The estimate for compound 4 lay 1.7-fold (0.22 log units) above the measured number; low and high end bracket the measured number.
By their numbers in this assay, from the lowest: compounds 2, 4 and 3 (each within the scatter of the next, the first and the last beyond it); then compound 1.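

In this assay, benzyloxy on this aromatic carbon puts oxygen in place of the amino nitrogen and leaves no hydrogen-bond donor, yet the steps are small: a 1.4-fold lower number from compound 3 to compound 4 (0.14 log units; within the scatter) and a 1.6-fold higher number from compound 2 to compound 4 (0.20 log units; within the scatter), both within the scatter. Against methylamino the same group gives a 4.5-fold lower number from compound 1 to compound 4 (0.66 log units; beyond the scatter), beyond the scatter, so among these four compounds a benzyl group at this place on either linking atom goes with the lower numbers. No measured evidence bears on this result. Still open, going by these compounds, is whether a 4-chlorobenzyloxy group, a thioether link or a longer chain before the phenyl ring would fit the same picture.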